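Compound 4: thiomorpholine amide on the longer chain

The compounds below may be only part of what the source reports. "The series", "measured", "known", "first", "only" and "open" are said of these compounds alone.

In an in vivo functional assay on the whole organism for inhibition, with Rattus norvegicus as the target (on this read-out lower numbers stand for an effect already at smaller amounts and higher numbers for an effect only at larger amounts of compound), compound 3 (`CCCCc1nc(C)c(CC(=O)N2CC(C)OC(C)C2)c(=O)n1Cc1ccc(-c2ccccc2-c2nnn[nH]2)cc1`) gives 0.029 mg/kg and compound 2 (`CCCCc1nc(C)c(CC(=O)N2CCC[C@H]2C(=O)OC)c(=O)n1Cc1ccc(-c2ccccc2-c2nnn[nH]2)cc1`) gives 0.043 mg/kg, which places them within the scatter of each other (a 1.5-fold lower number from compound 2 to compound 3 (0.17 log units; within the scatter)). Compound 1 (`CCCCc1nc(C)c(CCC(=O)OCC)c(=O)n1Cc1ccc(-c2ccccc2-c2nnn[nH]2)cc1`) gives 0.066 mg/kg, and compound 3 stands clear of it only modestly (a 2.3-fold lower number from compound 1 to compound 3 (0.36 log units; beyond the scatter)). The third measured step stays within the scatter (a 1.5-fold lower number from compound 1 to compound 2 (0.19 log units; within the scatter)).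

Compound 4 (`CCCCc1nc(C)c(CCC(=O)N2CCSCC2)c(=O)n1Cc1ccc(-c2ccccc2-c2nnn[nH]2)cc1`) brings this change: ((thiomorpholin-4-yl)carbonyl)methyl in place of (2,6-dimethylmorpholin-4-yl)carbonyl on a saturated chain carbon bound to an aromatic carbon. Within the data shown here, no measured compound carries thiomorpholin-4-yl, but compound 1 also has a carbonylmethyl group at this place. The measured steps are all small, the largest being the modest one from compound 1 (a 2.3-fold lower number from compound 1 to compound 3 (0.36 log units; beyond the scatter)), so nothing beyond the scatter is expected here.

The expected step is a 1.7-fold higher number from compound 3 to compound 4 (0.24 log units; within the scatter).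

For compound 4 the estimated value is 0.05 mg/kg, with an expected range from 0.02 mg/kg to 0.12 mg/kg.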

Compound 4, dose for half-maximal effect: 0.204 mg/kg
Compound 4: the middle estimate sits 4.1-fold (0.61 log units) below what was measured; measured number outside the range, above it.
By their numbers in this assay, from the lowest: compounds 3, 2 and 1 (each within the scatter of the next, the first and the last beyond it); then compound 4.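

In this assay, 2-((thiomorpholin-4-yl)carbonyl)ethyl gives larger steps than any seen earlier among these compounds (a 7.0-fold higher number from compound 3 to compound 4 (0.85 log units; beyond the scatter); a 4.7-fold higher number from compound 2 to compound 4 (0.68 log units; beyond the scatter)). With the chain unchanged, thiomorpholin-4-yl in place of ethoxy on a carbonyl carbon also raises the number (a 3.1-fold higher number from compound 1 to compound 4 (0.49 log units; beyond the scatter)), so chain length alone does not account for the loss. No available data bear on the reason for this loss.

Going by these compounds, it remains open whether the ring or the chain drives the loss: 2,6-dimethylmorpholin-4-yl on the longer chain and thiomorpholin-4-yl on the shorter chain would separate the two. On these data alone, a carboxylic acid in place of the ethyl ester of compound 1 is also open.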